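Moving the chloro group: from compound 3 to compound 4

The source may report more compounds than this note shows. Statements on the series, on what has been measured and on what is new or still open speak of the compounds shown alone.

In a functional assay on MDA-MB-231 cells (Homo sapiens) for antiproliferative activity, read by MTT assay, with a stated time of 72 h (a higher number here means a weaker inhibitor, a lower number a stronger inhibitor), compound 1 (`O=C(CCc1cccc2c1B(O)OC2)Nc1ccccc1`) gives 230 nM as the reference point. Compound 2 (`O=C(CCc1cccc2c1B(O)OC2)Nc1cccc(-c2cccc(F)c2)c1`) carries a 3-fluorophenyl group and gives 570 nM in the same test, while compound 3 (`O=C(CCc1cccc2c1B(O)OC2)Nc1cccc(-c2cccc(Cl)c2)c1`) carries a 3-chlorophenyl group and gives 250 nM there. Compound 3 therefore stands level with compound 1 and apart from compound 2. Adding the 3-chlorophenyl group gives a 1.1-fold higher number from compound 1 to compound 3 (0.04 log units; within the scatter) overall, and exchanging fluoro for chloro gives a 2.3-fold lower number from compound 2 to compound 3 (0.36 log units; beyond the scatter) on this read-out.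

Compound 4 (`O=C(CCc1cccc2c1B(O)OC2)Nc1cccc(-c2ccc(Cl)cc2)c1`) has not yet been measured. It has 4-chlorophenyl in place of 3-chlorophenyl on an aromatic carbon, meta to a large group, and the change amounts to 4-chlorophenyl in place of 3-chlorophenyl on an aromatic carbon in structural terms. Going by the values given here, no measured step moves a group around this ring, so the evidence is only indirect. The closest guides are a 2.3-fold lower number from compound 2 to compound 3 (0.36 log units; beyond the scatter) for the halogen exchange and a 2.5-fold higher number from compound 1 to compound 2 (0.39 log units; beyond the scatter) for adding the 3-fluorophenyl group, and both are modest. The expected change is a 1.2-fold higher number from compound 3 to compound 4 (0.08 log units; within the scatter) and so none beyond the scatter. Compound 4 is estimated at 300 nM with an expected range of 130 nM to 700 nM in this assay once tested.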

Compound 4, half-maximal inhibitory concentration: 260 nM
Compound 4: middle estimate off by 1.2-fold (0.06 log units), on the high side; the measured number falls inside the stated range.
By their numbers in this assay, from the lowest: compounds 1, 3 and 4 (each within the scatter of the next); then compound 2.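

In this assay, going by these compounds alone, the change from 3-chlorophenyl to 4-chlorophenyl gives a 1.0-fold higher number from compound 3 to compound 4 (0.02 log units; within the scatter) and is the first direct look at moving a group around this ring; for the chloro group, the two placements cannot be told apart on this read-out. The new compound also stays level with the parent that has hydrogen at this place, with a 1.1-fold higher number from compound 1 to compound 4 (0.05 log units; within the scatter), and it stands apart from the fluoro compound, with a 2.2-fold lower number from compound 2 to compound 4 (0.34 log units; beyond the scatter), so compound 2 remains the only one of the four set apart from the others. Nothing given here accounts for why the chloro group's placement leaves the number unchanged.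

On these data alone, what remains open is whether the fluoro group, moved in the same way, would also leave the number unchanged, or whether the gap between compound 2 and the chloro compounds depends on its placement. Also unsettled is whether the outer ring would tolerate a very different group as readily, such as an amine or a carboxylic acid in place of the chloro group.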